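Replacing pyridin-4-yl with 5-ethylthiophen-2-yl

A few compounds are considered here, and "the series" means these few. Any claim that something is new, unique, unknown or untested is made for them only; others in the source may bear on it.

Within the data shown here, in an ADME assay on Vero cells (Chlorocebus sabaeus) for cytotoxicity, read by MTT assay, with a stated time of 96 h (on this read-out lower numbers stand for higher toxicity in this test and higher numbers for lower toxicity in this test), compound 3 `COc1cc(NCc2ccncc2)ccc1-c1cnco1` gives 342000 nM, the highest of the three numbers so far. Compound 1 `COc1cc(NCc2ccc(C)o2)ccc1-c1cnco1` gives 45200 nM and compound 2 `COc1ccc(-c2cnco2)cc1NCc1ccc(C)s1` gives 42700 nM, two values within the usual scatter of each other. Compound 4 `CCc1ccc(CNc2ccc(-c3cnco3)c(OC)c2)s1` is still unmeasured. It carries 5-ethylthiophen-2-yl in place of pyridin-4-yl on a saturated chain carbon bound to a nitrogen on an aromatic ring. Among the measured compounds shown here, the one measured step that bears on this is a 7.6-fold higher number from compound 1 to compound 3 (0.88 log units; beyond the scatter), which brought pyridin-4-yl in place of 5-methylfuran-2-yl. Taking pyridin-4-yl away again, a step of similar size toward a lower number is expected, a 9.0-fold lower number from compound 3 to compound 4 (0.95 log units; beyond the scatter). Compound 4 is estimated at 38000 nM, within a range of 15000 nM to 90000 nM.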

Compound 4, half-maximal cytotoxic concentration: 13600 nM
Compound 4: middle estimate off by 2.8-fold (0.45 log units), on the high side; the whole stated range lies above it.
By their numbers in this assay, from the lowest: compound 4; then compounds 2 and 1 (each within the scatter of the next); then compound 3.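

At this position, on a saturated chain carbon bound to a nitrogen on an aromatic ring, 5-ethylthiophen-2-yl in place of pyridin-4-yl gives a 25-fold lower number from compound 3 to compound 4 (1.40 log units; beyond the scatter) in this assay and goes beyond simply undoing the earlier step. The two groups without a pyridine ring also differ, with a 3.3-fold lower number from compound 1 to compound 4 (0.52 log units; beyond the scatter) for 5-ethylthiophen-2-yl in place of 5-methylfuran-2-yl. Nothing measured here gives a reason for either step.

An unsubstituted thiophen-2-yl at this position could separate the contribution of the ethyl group from that of the ring. Going by these compounds, how an amine-bearing ring such as piperidin-4-yl would read also stays open.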